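Pyrrolidinyl methyl variant of an aromatic-core inhibitor: an outlook

This account rests on a few compounds, and the source may have more. Where it says the series, first, only, none or still open, it means among the compounds named here.

Measured compounds:
compound 1 `CCNC(=O)c1noc(-c2cc(C(C)C)c(O)cc2O)c1-c1cc(COCC(=O)OC)no1`: "not determined" (no result reported)
compound 2 `C=CNCc1cc(-c2c(C(=O)NCC)noc2-c2cc(C(C)C)c(O)cc2O)on1`: 43 nM
compound 3 `CCNC(=O)c1noc(-c2cc(C(C)C)c(O)cc2O)c1-c1cc(CNC(=O)CC)no1`: "not determined" (no result reported)

Three compounds with a shared core have been examined in a functional assay on A2780 cells (Homo sapiens) for inhibition (a lower number here means a stronger inhibitor, a higher number a weaker inhibitor), but a single number exists. Compound 1 and compound 3 carry different groups on the outer ring and have no reported result, so nothing can be said of them beyond their structures. In this assay compound 2 gives 43 nM, and compound 2 therefore stands alone as the only measured reference point in this set.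

The step of interest runs from compound 2 to compound 4 `CCNC(=O)c1noc(-c2cc(C(C)C)c(O)cc2O)c1-c1cc(CN2CCCC2)no1`. The change is pyrrolidin-1-yl in place of vinylamino on a saturated chain carbon bound to an aromatic carbon. The saturated chain carbon bound to an aromatic carbon keeps its place, and only the group attached to it changes.

Within the data shown here, no step between measured compounds is available to calibrate this change, so the expectation must rest on compound 2 alone. Compound 4 is expected to stay close to the single reference, with a step of a 1.2-fold lower number from compound 2 to compound 4 (0.09 log units; within the scatter) that is not expected to exceed the usual scatter in either direction. Compound 4 is therefore estimated at 35 nM in this assay, with a range from 12 nM to 110 nM.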

Compound 4, half-maximal inhibitory concentration: 55 nM
Beside the measured number, compound 4's estimate is 1.6-fold (0.20 log units) below it; measured number inside the range.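

In this assay, among these compounds, pyrrolidin-1-yl in place of vinylamino on a saturated chain carbon bound to an aromatic carbon gives a 1.3-fold higher number from compound 2 to compound 4 (0.11 log units; within the scatter), so this position, which had only a single number behind it before, now has one step, and that step cannot be told from the scatter. The exchange takes away the hydrogen-bond donor and the double bond outside aromatic rings and brings in a five-membered non-aromatic ring, yet this pair shows no separation in the read-out, so neither the donor nor the double bond is shown to be required here. No measured evidence ties this outcome to any feature of either group.

The steps to compound 1 and compound 3 cannot be read, so the ester and amide groups they carry on the same carbon cannot yet be set against the two amines. From the compounds shown here alone, whether a primary amine, a carboxylic acid or a longer chain at this place would also stay within the scatter remains open, and a single step cannot show how far this position tolerates change.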